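A few compounds are considered here, and "the series" means these few. Any claim that something is new, unique, unknown or untested is made for them only; others in the source may bear on it.

Measured in a functional assay on HL-60 cells (Homo sapiens) for inhibition, read by MTT assay, with a stated time of 72 h; on this read-out lower numbers stand for stronger inhibition and higher numbers for weaker inhibition:
- compound 1 `Cc1nc(-c2ccccc2)c(C(=O)N2CCN(c3cccc(Cl)c3Cl)CC2)o1`: 133 nM
- compound 2 `Cc1nc(-c2cccc(F)c2)c(C(=O)N2CCN(c3cccc(Cl)c3)CC2)o1`: 33.7 nM

Compound 1 holds the higher of the two numbers, at 133 nM. Compound 2 is lower at 33.7 nM, and this gap lies beyond the scatter. Only these two values are available, so they set a rough scale for the series and show no trend.

Compound 3 `Cc1ccc(N2CCN(C(=O)c3oc(C)nc3-c3ccccc3)CC2)cc1` has not yet been measured. Its structure differs from that of compound 1 at one place: 4-methylphenyl in place of 2,3-dichlorophenyl on an amine nitrogen in a ring. In words, 4-methylphenyl stands in place of 2,3-dichlorophenyl on an amine nitrogen in a ring.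

Going by the values given here, no measured pair of compounds differs in one place only, so the data give no direct guide to the size or direction of this change. The working expectation is therefore no shift beyond the scatter, with wide uncertainty on both sides. The estimated 1.3-fold higher number from compound 1 to compound 3 (0.11 log units; within the scatter) remains within the scatter. In this assay, the expected value for compound 3 is 170 nM, with an estimated range from 45 nM to 650 nM.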

Compound 3, half-maximal inhibitory concentration: > 1000 nM
Compound 3 gave a limit, no number; the forecaster's own chance of this, stated with the estimate: 5%; middle value at least 5.8-fold (0.76 log units) away from the limit.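

In this assay compound 3 gives > 1000 nM, which is a limit of the assay and not a number. Going by these compounds alone, this is the first comparison that changes one place only: with the rest of the core of compound 1 held constant, 4-methylphenyl in place of 2,3-dichlorophenyl on the amine nitrogen in the ring gives an at least 7.5-fold higher number from compound 1 to compound 3 (0.87 log units; beyond the scatter), so the result is sensitive to the aryl group at this position. The step has only a lower bound, and its full size cannot be read from this pair: the limit of > 1000 nM in this assay, at which 1 of the 3 values shown sits.

The step removes the two chlorines and introduces the methyl in a single change, so the pair does not separate the effect of either one, nor that of substituent placement on the aryl ring. From the compounds shown here alone, the response of this position to a plain phenyl, a pyridine ring, or an aryl group carrying an amine or a carboxylic acid remains open.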